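Oxazoline ethers: whole-animal read-out, bromo to nitro

This account rests on a few compounds, and the source may have more. Where it says the series, first, only, none or still open, it means among the compounds named here.

Measured so far:
compound 1, `COc1ccc(OCC2=NCCO2)cc1`: 90%
compound 2, `Brc1ccccc1OCC1=NCCO1`: 100%
compound 3, `Cc1cc(OCC2=NCCO2)ccc1Cl`: 100%

The three compounds share one core and differ only in the substitution on the aromatic ring. In a toxicity assay on the whole organism with Rattus norvegicus as the target, at a dose of 400 mg/kg by the oral route (a lower number here means a weaker effect, a higher number a stronger effect of the compound at the dose given), compound 2 gives 100%, the same number at the digits shown as compound 3 with 100%; the two stand together at the top of the three values, with no difference between them beyond the scatter. The furthest from compound 2 on the numbers is compound 1, which gives 90% in this assay, and that gap too lies within the scatter, so nothing separates the three at the level of the measurement.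

Compound 4, `O=[N+]([O-])c1ccccc1OCC1=NCCO1`, has not yet been measured in this assay. It is set apart from compound 2 by one change: nitro in place of bromo on an aromatic carbon. The nitro group sits ortho to a group of 7 heavy atoms, where the bromo stood. Among the measured compounds shown here, no comparison between two measured compounds covers this change, so there is no step to lean on.

Since compound 2 gives 100% and both other measured compounds sit within the scatter of it, the step of a number 5 percentage points lower from compound 2 to compound 4 (within the scatter) is expected to be none beyond the scatter, with the risk lying downward rather than upward. For compound 4 the estimate in this assay is 95%, within a range from 80% to 100%.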

Compound 4, a percentage reported as activity, at one dose (the size of the read-out at that dose, not a potency): 90%
Compound 4: middle estimate off by 5 percentage points, on the high side, and the stated range covers the measured number.
By their numbers in this assay, from the lowest: compounds 1, 4, 2 and 3 (each within the scatter of the next).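

In this assay, among the compounds shown here, nitro in place of bromo on an aromatic carbon, ortho to a group of 7 heavy atoms, gives a number 10 percentage points lower from compound 2 to compound 4 (within the scatter), and this is the first step read between two measured compounds that differ in one place. At this position, then, the 1 heavy atom of bromo can give way to the 3 heavy atoms of nitro, with 2 hydrogen-bond acceptors entering where bromo has 0, without a change in the read-out beyond the scatter at this single dose. Nothing among the data shown accounts for this result or ties it to any property of either group.

For the compounds shown here, it remains open whether an amine, a carboxylic acid or a longer alkyl chain at this position would also leave this assay within the scatter of compound 2, since bromo and nitro are the only two groups compared here. A single pair also cannot show whether the same change would read alike on a ring that carries other substituents, or at a different dose.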